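Swapping a benzyl group for a phenyl group

The compounds below may be only part of what the source reports. "The series", "measured", "known", "first", "only" and "open" are said of these compounds alone.

Compound 1 `COc1ccccc1-n1cc(COc2cccc3cnc(Nc4cccc(Cl)c4)nc23)nn1`: > 25000 nM (a limit of the assay, not a number)
Compound 2 `Clc1cccc(Nc2ncc3cccc(OCc4cn(Cc5c(Cl)cccc5Cl)nn4)c3n2)c1`: 5000 nM

Among the measured compounds shown here, in a functional assay on NCI-H727 cells (Homo sapiens) for cytotoxicity, read by cell counting, with a stated time of 48 h (on this read-out higher numbers stand for weaker inhibition and lower numbers for stronger inhibition), compound 2 gives 5000 nM, the only actual number so far. Compound 1 gives > 25000 nM, which is a limit.

The next molecule, compound 3 `Clc1cccc(Nc2ncc3cccc(OCc4cn(-c5ccc(Br)cc5)nn4)c3n2)c1`, keeps the shared core and changes one group: 4-bromophenyl in place of 2,6-dichlorobenzyl on an aromatic nitrogen. In words, 4-bromophenyl replaces 2,6-dichlorobenzyl on an aromatic nitrogen.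

For the measured compounds named here, one measured step bears on this change. Replacing 2-methoxyphenyl with 2,6-dichlorobenzyl at the same place gave an at least 5.0-fold lower number from compound 1 to compound 2 (0.69 log units; beyond the scatter). Going by the values given here, compound 3 goes the opposite way, from a benzyl group back to a phenyl group, although its phenyl ring carries a different substituent from the one in compound 1. A single step is thin evidence, but it points towards weaker inhibition, so a higher number is expected, and this assay may report only a limit.

The expected change is a 3.0-fold higher number from compound 2 to compound 3 (0.48 log units; beyond the scatter). For compound 3 the estimated value is 15000 nM, with an expected range of 5000 nM to 40000 nM.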

Compound 3, half-maximal inhibitory concentration: 8000 nM
For compound 3 the middle estimate is 1.9-fold (0.27 log units) above the measured one; the range from low to high includes it.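

The result changes how the earlier step reads. Putting 4-bromophenyl in place of 2,6-dichlorobenzyl on the aromatic nitrogen gives a 1.6-fold higher number from compound 2 to compound 3 (0.20 log units; within the scatter), so on this measure a phenyl group can do as well as a benzyl group at this position, and the benzyl form is not required. The comparison between the two phenyl groups, with 4-bromophenyl in place of 2-methoxyphenyl, gives an at least 3.1-fold lower number from compound 1 to compound 3 (0.49 log units; beyond the scatter), which shows that the choice of group on the phenyl ring matters here as well. The true size of that step stays unknown because compound 1 stands at a limit: the limit of > 25000 nM in this assay, at which 1 of the 3 values shown sits.

The 4-bromophenyl and 2-methoxyphenyl groups differ both in their substituent and in where it sits on the ring, so the compounds shown cannot separate these two changes. Also open, as far as these compounds go, is how this position would respond to a plain phenyl ring, to a phenyl ring carrying an amine or a carboxylic acid, or to a longer chain between the ring and the nitrogen.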